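The source may report more compounds than this note shows. Statements on the series, on what has been measured and on what is new or still open speak of the compounds shown alone.

Measured compounds:
compound 1, `CCc1ccccc1N(Cc1nnc(Cc2ccc(Cl)cc2)o1)S(=O)(=O)c1ccc(C)cc1`, 398 nM
compound 2, `COc1ccc(Cc2nnc(CN(c3cccc(C(F)(F)F)c3C)S(=O)(=O)c3ccc(C)cc3)o2)cc1`, 63.1 nM
compound 3, `Cc1ccc(S(=O)(=O)N(Cc2nnc(Cc3ccccc3F)o2)c2cccc(Cl)c2C)cc1`, 501 nM

All three were tested in an assay on CHO cells for displacement of a labelled ligand from prostaglandin E2 receptor EP1 subtype (Homo sapiens); on this read-out higher numbers stand for weaker inhibition and lower numbers for stronger inhibition. Compound 3 gives the highest of the three numbers; compound 1 sits within the usual scatter of it, while compound 2 lies beyond the scatter at a clearly lower number. Compound 4 `COc1ccc(Nc2nnc(CN(c3cccc(Cl)c3C)S(=O)(=O)c3ccc(C)cc3)o2)cc1` has not been measured. It differs from compound 3 in one place: (4-methoxyphenyl)amino in place of 2-fluorobenzyl on an aromatic carbon. Among the compounds with values here, no measured pair shows this same change, so its size cannot be read off directly. Compound 2, whose corresponding group also carries a methoxy group, shows a number well below that of compound 3, which hints that a move toward a lower number is plausible. The step expected from compound 3 to compound 4 is a 3.1-fold lower number from compound 3 to compound 4 (0.50 log units; beyond the scatter). Compound 4 is estimated at 160 nM, between 40 nM and 630 nM.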

Compound 4, half-maximal inhibitory concentration: 31.6 nM
Compound 4: middle estimate off by 5.1-fold (0.70 log units), on the high side, outside the stated range (below it).
By their numbers in this assay, from the lowest: compounds 4 and 2 (each within the scatter of the next); then compounds 1 and 3 (each within the scatter of the next).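

In this assay, within the data shown here, the replacement of 2-fluorobenzyl by (4-methoxyphenyl)amino on this aromatic carbon gives a 16-fold lower number from compound 3 to compound 4 (1.20 log units; beyond the scatter) and is the first direct reading of a change at this position. It shows that the position is sensitive to what it carries, with a large step beyond the scatter. Nothing available explains the size of this step. The change alters the link and the ring substituents at once, and the compounds shown do not separate the two. From the compounds shown here alone, it remains open whether a plain phenylamino group, without the methoxy group, or a phenoxy group would give a similar number.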